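Switching the aryl arm of compound 3 to a direct thiophene

This account rests on a few compounds, and the source may have more. Where it says the series, first, only, none or still open, it means among the compounds named here.

Among the compounds with values here, compound 3 `NCc1ccncc1CN(Cc1nc2ccccc2[nH]1)C1CCCc2cccnc21` stands second highest of the three numbers so far in a functional assay on CEM-CCRF cells for antagonist activity at C-X-C chemokine receptor type 4 (Homo sapiens), read by calcium flux (on this read-out lower numbers stand for stronger inhibition and higher numbers for weaker inhibition), where compound 3 gives 160 nM. Its nearest neighbour is compound 1 `NCc1cc(F)ccc1CN(Cc1nc2ccccc2[nH]1)C1CCCc2cccnc21`, which in this assay gives 219 nM; the step of a 1.4-fold lower number from compound 1 to compound 3 (0.14 log units; within the scatter) is within the scatter. Its furthest is compound 2 `NCc1cc(CO)ccc1CN(Cc1nc2ccccc2[nH]1)C1CCCc2cccnc21`, which in this assay gives 11 nM; the step of a 15-fold higher number from compound 2 to compound 3 (1.16 log units; beyond the scatter) is large, as is a 20-fold lower number from compound 1 to compound 2 (1.30 log units; beyond the scatter).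

Compound 4 `NCc1cscc1N(Cc1nc2ccccc2[nH]1)C1CCCc2cccnc21` differs from compound 3 by a group of 7 heavy atoms (5 carbon, 1 nitrogen, 1 sulfur; one five-membered aromatic ring with 1 hetero atom) in place of a group of 9 heavy atoms (7 carbon, 2 nitrogen; one six-membered aromatic ring with 1 hetero atom), on an amine nitrogen. Within the data shown here, no measured step touches this kind of change: the two known steps into compound 3 swap one six-membered ring with a methylene linker for another, while here the linker is gone and the ring shrinks to five members. Those steps show that the arm can move the number by little or by much, so the expected step of a 2.2-fold higher number from compound 3 to compound 4 (0.34 log units; beyond the scatter) is uncertain, with a loss seen as somewhat more likely than a gain given that compound 2 already marks the low end at 11 nM. The expected value for compound 4 in this assay is 350 nM, in the range 80 nM to 1500 nM.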

Compound 4, half-maximal inhibitory concentration: 13 nM
The estimate for compound 4 lay 27-fold (1.43 log units) above the measured number; the whole stated range lies above it.
By their numbers in this assay, from the lowest: compounds 2 and 4 (each within the scatter of the next); then compounds 3 and 1 (each within the scatter of the next).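

In this assay, the change on the amine nitrogen gives a large step from each of the two weaker compounds (a 12-fold lower number from compound 3 to compound 4 (1.09 log units; beyond the scatter); a 17-fold lower number from compound 1 to compound 4 (1.23 log units; beyond the scatter)). Within the data shown here, this shows that the arm at this position can reach the low end of the series with a five-membered aromatic ring with 1 hetero atom, joined directly to the amine nitrogen, and without the six-membered ring and methylene linker of the earlier compounds; compound 4 and compound 2 lie within the scatter of each other, so the two quite different arms cannot be told apart on this read-out. Nothing available explains the size of this gain.

Because the ring and the linker change together from compound 3 to compound 4, the compounds shown do not separate the effect of ring size from that of losing the methylene linker. As far as these compounds go, a thiophene held on the amine nitrogen through a methylene linker, or a phenyl or furan ring joined directly, would bear on that question, and whether a hydroxymethyl group on the thiophene adds anything also stays open.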